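Methyl in Place of Methylsulfonyl: Expected Clearance Change

The source may hold more compounds than are shown below. What is called first, only, known or untested is meant among the compounds shown, and "the series" means these compounds.

The measured compounds in an ADME assay on microsomes from liver (Homo sapiens) for metabolic stability, read by LC-MS, using NADPH, with a stated time of 45 min, tested at 0.5 uM; a lower number here means slower removal, a higher number faster removal of the compound:
Compound 1, `CS(=O)(=O)C1CCN(C(=O)CCSc2nc3cc(Cl)ccc3o2)C1`, gives < 0.4 mL/min/g, which is a limit of the assay rather than a number.
Compound 2, `O=C(CCSc1nc2cc(F)c(F)cc2o1)N1CCCC1`, gives 6.5 mL/min/g.
Compound 3, `O=C(CCSc1nc2ncccc2o1)N1CCCC1`, gives 0.7 mL/min/g.

Compound 1 therefore stands at the lowest point the assay can report (the limit of < 0.4 mL/min/g in this assay, at which 1 of the 3 values shown sits); its true clearance lies somewhere under that limit and is not known more exactly. Compounds 2 and 3 differ from compound 1 elsewhere in the structure and show numbers rather than limits, with compound 2 sitting well above compound 3. Within the data shown here, no pair among the three differs in only one place, so no single structural step has been measured here.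

Compound 4, `CC1CCN(C(=O)CCSc2nc3cc(Cl)ccc3o2)C1`, differs from compound 1 in one place: methyl in place of methylsulfonyl on a saturated ring carbon. The group that leaves is larger than the one that enters, and the rest of the structure is unchanged. Among the measured compounds shown here, with no measured step of this kind to lean on, and compound 1 known only as a limit, the expectation in this assay is a faster removal, a step beyond the usual scatter, though its size is uncertain. For compound 4 the estimated value is 3 mL/min/g, with a range from 0.8 mL/min/g to 10 mL/min/g. This corresponds to an expected step of an at least 7.5-fold higher number from compound 1 to compound 4 (0.87 log units; beyond the scatter) in this assay.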

Compound 4, intrinsic clearance in a liver preparation (reported as CLH), per the amount of preparation that the assay uses: 10.1 mL/min/g
For compound 4 the middle estimate is 3.4-fold (0.53 log units) below the measured one; the measured number lies above the stated range.
By their numbers in this assay, from the lowest: compound 3; then compounds 2 and 4 (each within the scatter of the next). At a limit, below all of these: compound 1.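

In this assay, the change at this ring carbon can now be read on its own: methyl in place of methylsulfonyl gives an at least 25-fold higher number from compound 1 to compound 4 (1.40 log units; beyond the scatter). The earlier compounds shown here differed from one another in more than one place, so none of them could tie a shift in clearance to a single group, whereas compound 1 and compound 4 share the rest of the structure. This one substituent on the saturated ring, two ring bonds from the ring nitrogen, therefore makes a large difference to how fast the compound is removed, and the true step could be larger still, since compound 1 stands at a limit of the assay and not at a number: the limit of < 0.4 mL/min/g in this assay, at which 1 of the 4 values shown sits.

The compounds shown leave open where a hydroxyl group, a primary amine or a carboxylic acid on the same ring carbon would fall in this assay, and so whether removing methylsulfonyl or adding methyl matters more. They also leave open whether the same swap would give a step of this size on a different core, or at another carbon of the saturated ring.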